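Replacing the Dimethoxyphenyl Ring on the Shared Core

The source may report more compounds than this note shows. Statements on the series, on what has been measured and on what is new or still open speak of the compounds shown alone.

Measured compounds:
Compound 1 `COc1ccc(OC)c(N2C(=O)CSC2c2cccc(C(=O)NCCCCc3ccccc3)c2)c1` gives > 1000 nM in a functional assay on HOS-TE85 cells (Homo sapiens) for inhibition, read by CCK-8 assay, with a stated time of 72 h; a lower number here means a stronger inhibitor, a higher number a weaker inhibitor.
Compound 2 `CCOC(=O)c1sc(N2C(=O)CSC2c2cccc(C(=O)NCCCCn3cccn3)c2)nc1C` gives 430 nM in this assay.

Compound 1 sits only at a limit of this assay, so where it stands on the numbers shown is a bound, not a value, as recorded in the limit of > 1000 nM in this assay, at which 1 of the 2 values shown sits. Among the measured compounds shown here, compound 2 is the one compound with a numerical reading in this assay, and no step between two measured compounds that differ in a single place is available, so the two values can only be taken as they stand.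

Compound 3 `O=C(NCCCCc1ccccc1)c1cccc(C2SCC(=O)N2c2ccccc2F)c1` derives from compound 1 by 2-fluorophenyl in place of 2,5-dimethoxyphenyl on an amide-type nitrogen in a ring. Because compound 1 itself is known only as a limit (the limit of > 1000 nM in this assay, at which 1 of the 2 values shown sits), the starting point of this step is uncertain, and the change is expected to be modest: the step that the limit leaves unreadable from compound 1 to compound 3 is estimated to stay within or only slightly beyond the usual scatter, in either direction. Compound 3 is therefore expected to give about 2000 nM, between 500 nM and 8000 nM, with a fair chance that it also returns a limit in this assay.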

Compound 3, half-maximal inhibitory concentration: 34.1 nM
For compound 3 the middle estimate is 59-fold (1.77 log units) above the measured one; the measured number lies below the stated range.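

On the shared core, the group on the amide-type nitrogen in a ring proves to be a position where a single change counts heavily: in this assay, 2-fluorophenyl in place of 2,5-dimethoxyphenyl gives an at least 29-fold lower number from compound 1 to compound 3 (1.46 log units; beyond the scatter). That step is a bound on the size of the change and not its exact size, since compound 1 stands at a limit: the limit of > 1000 nM in this assay, at which 1 of the 3 values shown sits. Compound 3 keeps the rest of compound 1, so the step belongs to this one position, but it joins the loss of both methoxy groups with the gain of a fluorine, and a single step cannot separate the two or give a cause for the change.

Going by these compounds, it remains open whether the fluorine itself matters or whether removing the methoxy groups is enough, a question that an unsubstituted phenyl, a 2-chlorophenyl or a 2-methoxyphenyl on the same nitrogen would address. On these data alone, it is also open whether 2-fluorophenyl has a comparable effect when the amide carries the side chain of compound 2 or a shorter chain.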